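Chloro to Bromo: an Expected Small Shift in Potency

This account rests on a few compounds, and the source may have more. Where it says the series, first, only, none or still open, it means among the compounds named here.

Of the compounds shown here, two have so far been measured in a functional assay on A549 cells (Homo sapiens) for antiproliferative activity, read by MTT assay, with a stated time of 48 h; on this read-out higher numbers stand for weaker inhibition and lower numbers for stronger inhibition. Compound 1 `N#CC1=C(N)Oc2cc3oc(-c4ccccc4)cc(=O)c3c(O)c2C12C(=O)Nc1ccccc12` gives 37600 nM in this assay. Compound 2 `N#CC1=C(N)Oc2cc3oc(-c4ccccc4)cc(=O)c3c(O)c2C12C(=O)Nc1cc(Cl)ccc12` carries a chloro group where compound 1 carries hydrogen, and in this assay compound 2 gives 8470 nM. The step between them is a 4.4-fold lower number from compound 1 to compound 2 (0.65 log units; beyond the scatter). Compound 2 thus stands at the lower of the two numbers, and its nearest and only neighbour, compound 1, sits at a number beyond the scatter above it.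

Compound 3 `N#CC1=C(N)Oc2cc3oc(-c4ccccc4)cc(=O)c3c(O)c2C12C(=O)Nc1cc(Br)ccc12` is not yet measured. Among the measured compounds shown here, its single difference from compound 2 is bromo in place of chloro on an aromatic carbon. For the measured compounds named here, the only measured step that bears on a change at this carbon is a 4.4-fold lower number from compound 1 to compound 2 (0.65 log units; beyond the scatter), and that step replaced hydrogen, not one halogen by another. Exchanging one heavy atom for one heavy atom of the same kind of group is a smaller move than adding a group where none stood, so the expected step is a 1.4-fold lower number from compound 2 to compound 3 (0.15 log units; within the scatter), a change at or near the scatter. In this assay compound 3 is therefore estimated to give 6000 nM, with a likely range from 2500 nM to 15000 nM.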

Compound 3, half-maximal inhibitory concentration: 9340 nM
Beside the measured number, compound 3's estimate is 1.6-fold (0.19 log units) below it; the measured number falls inside the stated range.
By their numbers in this assay, from the lowest: compounds 2 and 3 (each within the scatter of the next); then compound 1.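

In this assay, putting bromo in place of chloro on this aromatic carbon gives a 1.1-fold higher number from compound 2 to compound 3 (0.04 log units; within the scatter) and so leaves the two halogens indistinguishable on this read-out. Measured against the unsubstituted compound, bromo gives a 4.0-fold lower number from compound 1 to compound 3 (0.60 log units; beyond the scatter) and chloro gave a 4.4-fold lower number from compound 1 to compound 2 (0.65 log units; beyond the scatter), so the improvement over hydrogen at this carbon no longer rests on a single substituent but appears with two different halogens. No measurement here explains why chloro and bromo match or why either one differs from hydrogen.

The compounds shown leave open whether this improvement belongs to halogens in particular or would also appear with quite different groups on the same carbon, such as fluoro, methyl, methoxy, an amine or a carboxylic acid. They also cannot tell whether the choice of carbon matters, since chloro and bromo have been compared only at this one place on the ring, and a halogen on another carbon of the same ring could give a different result.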